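Phenyl for trifluoromethylphenoxy on a tetrazolyl ketone core

The compounds below may be only part of what the source reports. "The series", "measured", "known", "first", "only" and "open" are said of these compounds alone.

The series is built on a shared core and was read in a physicochemical assay for lipophilicity, read by HPLC, tested at 5 mM; a lower number here means a more polar compound, a higher number a more lipophilic compound. Compound 1 `CC(Oc1ccc(Oc2ccc(C(F)(F)F)cc2)cc1)C(=O)Cn1nnc(-c2ccccc2)n1` gives 6.2 in this assay. Compound 2 `CC(Oc1ccc(-c2ccccc2)cc1)C(=O)Cn1nnc(-c2ccccc2)n1` gives 5.3 in this assay, and the step of a number 0.90 log units lower from compound 1 to compound 2 (beyond the scatter) comes from the change (phenyl in place of 4-(trifluoromethyl)phenoxy on an aromatic carbon). Compound 3 `COC(=O)c1ccc(-c2nnn(CC(=O)C(C)Oc3ccc(Oc4ccc(C(F)(F)F)cc4)cc3)n2)cc1` gives 6.2 in this assay; the step of no change at the digits printed from compound 1 to compound 3 (within the scatter) reflects the difference between the two cores, (methoxycarbonyl in place of hydrogen on an aromatic carbon), so compound 3 and compound 1 stand level within the scatter, together the highest of the three numbers. Compound 4 `COC(=O)c1ccc(-c2nnn(CC(=O)C(C)Oc3ccc(-c4ccccc4)cc3)n2)cc1` has not yet been measured in this assay. It differs from compound 3 by phenyl in place of 4-(trifluoromethyl)phenoxy on an aromatic carbon, which is the same change as that from compound 1 to compound 2, at the same kind of place on the ring. Going by the values given here, the step from compound 3 to compound 4 in this assay is therefore expected to be a number 0.90 log units lower from compound 3 to compound 4 (beyond the scatter), resting on the one precedent measured for compound 1 and compound 2 in a number 0.90 log units lower from compound 1 to compound 2 (beyond the scatter). Compound 4 is estimated to give about 5.3 in this assay, between 4.9 and 5.7.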

Compound 4, partition coefficient: 5.4
Beside the measured number, compound 4's estimate is 0.10 log units below it, and the stated range covers the measured number.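

In this assay, phenyl in place of 4-(trifluoromethyl)phenoxy gives a step of a number 0.80 log units lower from compound 3 to compound 4 (beyond the scatter) on the core bearing methoxycarbonyl, and a step of a number 0.90 log units lower from compound 1 to compound 2 (beyond the scatter) on the core of compound 1, so the change carries over between these two cores in the same direction and beyond the scatter in both. With phenyl in place, methoxycarbonyl in place of hydrogen gives a number 0.10 log units higher from compound 2 to compound 4 (within the scatter), which matches the absence of a change seen with 4-(trifluoromethyl)phenoxy in place. Going by these compounds alone, this is one change read on only two cores, so it does not show that the step would hold on any other core, and nothing measured here explains why it carries over.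

The compounds shown leave open how the same step would read with a carboxylic acid or an amine in place of methoxycarbonyl. They also leave open how a longer alkyl chain in place of phenyl would compare on either core.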